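Replacing an aroyl group with a chain in a diacylhydrazine series

The compounds below may be only part of what the source reports. "The series", "measured", "known", "first", "only" and "open" are said of these compounds alone.

Among the compounds with values here, compound 2 `COc1cccc(C(=O)NN(C(=O)c2cc(C)cc(C)c2)C(C)(C)C)c1` gives 66.1 nM in an assay on cells for agonist activity at ecdysone receptor (Bombyx mori), read by a luciferase reporter, with a stated time of 24 h (on this read-out lower numbers stand for an effect already at smaller amounts and higher numbers for an effect only at larger amounts of compound), the second highest of the three numbers measured so far. Within the data shown here, its nearest neighbour is compound 1 `COc1cccc(C(=O)NN(C(=O)c2ccccc2Cl)C(C)(C)C)c1`, which in this assay gives 52.5 nM; the step of a 1.3-fold higher number from compound 1 to compound 2 (0.10 log units; within the scatter) is the only single-point change measured and it concerns the other carbonyl carbon. Furthest away is compound 3 `CCCCCC(=O)N(NC(=O)c1ccc(CC)cc1)C(C)(C)C`, which in this assay gives 2820 nM; compound 3 carries a chain on one carbonyl carbon where compound 2 carries an aromatic ring, but the two differ in more than one place, so only their two values can be compared.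

Compound 4 `CCCCC(=O)NN(C(=O)c1cc(C)cc(C)c1)C(C)(C)C` is compound 2 with butyl in place of 3-methoxyphenyl on a carbonyl carbon. Among the measured compounds shown here, no measured step covers exactly this change. The comparison of compound 2 with compound 3 points to a much higher number once a chain replaces an aromatic ring on a carbonyl carbon. The step of a 23-fold higher number from compound 2 to compound 4 (1.36 log units; beyond the scatter) is therefore expected in this assay. Compound 4 is estimated at 1500 nM, within a range of 300 nM to 7000 nM, the uncertainty reflecting that compound 3 also differs elsewhere.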

Compound 4, half-maximal effective concentration: 1860 nM
The estimate for compound 4 lay 1.2-fold (0.09 log units) below the measured number; low and high end bracket the measured number.
By their numbers in this assay, from the lowest: compounds 1 and 2 (each within the scatter of the next); then compounds 4 and 3 (each within the scatter of the next).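

In this assay, within the data shown here, butyl in place of 3-methoxyphenyl on a carbonyl carbon gives a 28-fold higher number from compound 2 to compound 4 (1.45 log units; beyond the scatter) as the first single-place reading of a chain for an aromatic ring, and it lies beyond the scatter, whereas the change on the other carbonyl carbon (a 1.3-fold higher number from compound 1 to compound 2 (0.10 log units; within the scatter)) stays within it. The change removes the ring and the hydrogen-bond acceptor together, so compound 4 cannot assign the rise to either one alone. Nothing measured here accounts for the size of this step.

From the compounds shown here alone, whether cyclohexyl or a plain phenyl without the methoxy group would hold the number near that of compound 2 remains open. Going by these compounds, how a longer chain such as hexyl would read at this place also remains open.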